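The source may report more compounds than this note shows. Statements on the series, on what has been measured and on what is new or still open speak of the compounds shown alone.

Measured so far:
compound 1 `Cc1ccccc1N(C)C(=O)c1ccc(-c2ccc(OS(N)(=O)=O)c(Cl)c2)o1` — 25 nM
compound 2 `Cc1ccccc1N(C)C(=O)c1ccc(-c2ccc(OS(N)(=O)=O)c(F)c2)o1` — 17 nM
compound 3 `Cc1ccccc1N(C)C(=O)c1ccc(-c2ccc(OS(N)(=O)=O)cc2Cl)o1` — 27 nM

In an assay on T47D cells for inhibition of Steryl-sulfatase (Homo sapiens), read by HPLC, with a stated time of 24 h (on this read-out higher numbers stand for weaker inhibition and lower numbers for stronger inhibition), the three values all lie close together. For the measured compounds named here, from compound 1 to compound 2 the only change is fluoro in place of chloro on an aromatic carbon; it gave a 1.5-fold lower number from compound 1 to compound 2 (0.17 log units; within the scatter). Compound 3 shares its atoms with compound 1 but joins them differently; how the two cores differ is not broken down here.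

Compound 4 `Cc1ccccc1N(C)C(=O)c1ccc(-c2ccc(OS(N)(=O)=O)cc2F)o1` has not been measured. It differs from compound 3 by fluoro in place of chloro on an aromatic carbon. This is the same kind of change as between compound 1 and compound 2, but the place is not identical: there the carbon was ortho to a sulfamoyloxy group and meta to a large group, here it is ortho to a large group and meta to a sulfamoyloxy group.

Given that compound 3 gives 27 nM and the earlier swap gave a 1.5-fold lower number from compound 1 to compound 2 (0.17 log units; within the scatter), compound 4 is expected to show a 1.4-fold lower number from compound 3 to compound 4 (0.15 log units; within the scatter). The estimate for compound 4 is 19 nM, from 9 nM to 40 nM.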

Compound 4, half-maximal inhibitory concentration: 12 nM
Beside the measured number, compound 4's estimate is 1.6-fold (0.20 log units) above it; low and high end bracket the measured number.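

On the core of compound 3, fluoro in place of chloro gives a 2.3-fold lower number from compound 3 to compound 4 (0.35 log units; beyond the scatter) in this assay. Set beside the same swap on the core of compound 1, the two steps cannot be told apart, so the swap carries over between these two cores as far as this assay can resolve: the same change on two cores in this assay, a 1.5-fold lower number (0.17 log units; within the scatter) from compound 1 to compound 2 and a 2.3-fold lower number (0.35 log units; beyond the scatter) from compound 3 to compound 4, 1.5-fold (0.18 log units) apart, within the scatter of two such steps. For the compounds shown here, this rests on only two pairs, and only the step on the core of compound 3 lies beyond the scatter, so it does not show a general rule for this swap on other cores.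

The compounds shown leave open what other groups on these aromatic carbons, such as methoxy, nitrile or trifluoromethyl, would give. They also leave open how a plain hydrogen there would compare with chloro and fluoro.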